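Swapping the Aryl Ketone Group in Compound 1

The compounds below may be only part of what the source reports. "The series", "measured", "known", "first", "only" and "open" are said of these compounds alone.

Three compounds have numbers in a functional assay on PC-3 cells (Homo sapiens) for cytotoxicity, read by MTT assay, with a stated time of 48 h; on this read-out lower numbers stand for stronger inhibition and higher numbers for weaker inhibition. Compound 1 `COc1cc(-c2nnc3n2NC(c2ccco2)C(C(=O)c2ccc(Br)cc2)S3)cc(OC)c1OC` gives 36400 nM, the lowest of the two numbers. Compound 2 `COc1cc(-c2nnc3n2NC(c2cccs2)C(C(=O)c2ccccc2)S3)cc(OC)c1OC` gives 86300 nM, a higher number beyond the usual scatter. Compound 3 `COc1cc(C(=O)C2Sc3nnc(-c4cc(OC)c(OC)c(OC)c4)n3NC2c2cccs2)cc(OC)c1OC` reaches only a limit of this assay, > 100000 nM. Among the measured compounds shown here, the one change between measured compounds that sits on the carbonyl carbon is an at least 1.1-fold higher number from compound 2 to compound 3 (0.06 log units; that floor lies within the scatter), and since it ends at a limit (the limit of > 100000 nM in this assay, at which 1 of the 3 values shown sits), only a floor can be given for it.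

Compound 4 `COc1cc(-c2nnc3n2NC(c2ccco2)C(C(=O)c2cccc4ccccc24)S3)cc(OC)c1OC` differs from compound 1 by naphthalen-1-yl in place of 4-bromophenyl on a carbonyl carbon. For the measured compounds named here, no measured pair shows this change, and the only measured step on the carbonyl carbon, an at least 1.1-fold higher number from compound 2 to compound 3 (0.06 log units; that floor lies within the scatter), does not resolve beyond the scatter. A step beyond the scatter is therefore not expected in this assay. Compound 4 is estimated at 36000 nM, with a range from 12000 nM to 110000 nM. This estimate amounts to a 1.0-fold lower number from compound 1 to compound 4 (0.00 log units; within the scatter).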

Compound 4, half-maximal inhibitory concentration: > 100000 nM
Compound 4 ended at the assay's limit (the forecaster's own chance of this, stated with the estimate: 25%); at least 2.7-fold (0.44 log units) between middle value and limit.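

On a carbonyl carbon, naphthalen-1-yl in place of 4-bromophenyl gives an at least 2.7-fold higher number from compound 1 to compound 4 (0.43 log units; beyond the scatter) in this assay. Among the compounds shown here, this is the first step at this position to clear the scatter, whereas the earlier step, an at least 1.1-fold higher number from compound 2 to compound 3 (0.06 log units; that floor lies within the scatter), could not show that the group here matters. Compound 4 sits at a limit rather than at a number, so the new step is only a floor, and its true size stays unknown: the limit of > 100000 nM in this assay, at which 2 of the 4 values shown sit.

The compounds shown leave open whether the second aromatic ring of naphthalen-1-yl or the absence of bromine accounts for the step, a question that a plain phenyl, 4-chlorophenyl or naphthalen-2-yl on the core of compound 1 could help to separate. Also open, as far as these compounds go, is how this position would respond to an amine or a carboxylic acid on the ring.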